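The compounds below may be only part of what the source reports. "The series", "measured", "known", "first", "only" and "open" are said of these compounds alone.

Working notes on the series.

Compound 1 `CC(C)(C)c1ccc(-n2c(-c3cccnc3N)nc3cccnc32)cc1` stands lowest of the three compounds measured in an in vitro assay on Sf9 cells for binding affinity to RAC-alpha serine/threonine-protein kinase (Homo sapiens), tested at 30 uM (on this read-out higher numbers stand for stronger stabilisation of the target against heat and lower numbers for weaker stabilisation of the target), giving 1.9 degrees C. Compound 3 `CC(=O)NCc1ccc(-n2c(-c3cccnc3N)nc3cccnc32)cc1` gives 2.3 degrees C, and the step of a number 0.40 degrees C higher from compound 1 to compound 3 (within the scatter) lies within the scatter. Compound 2 `Nc1ncccc1-c1nc2cccnc2n1-c1ccc(CNC(=O)C2CCCCC2)cc1` gives 5.7 degrees C, a step of a number 3.8 degrees C higher from compound 1 to compound 2 (beyond the scatter). Between the two amides, the step of a number 3.4 degrees C lower from compound 2 to compound 3 (beyond the scatter) shows that the amide bearing the ring separates from the one bearing methyl.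

Compound 4 `Nc1ncccc1-c1nc2cccnc2n1-c1ccc(NC(=O)c2ccccc2)cc1` is the next compound to be measured. Relative to compound 1 the change is benzamido in place of tert-butyl on an aromatic carbon. Among the compounds with values here, the steps that bear on it are the two that introduce or vary an amide at this position: the gain in a number 3.8 degrees C higher from compound 1 to compound 2 (beyond the scatter) and the loss in a number 3.4 degrees C lower from compound 2 to compound 3 (beyond the scatter). Compound 4 carries an amide with a ring, as compound 2 does, though without the methylene and with an aromatic ring instead. A modest gain beyond the scatter is therefore expected, smaller or equal to that of compound 2. The step from compound 1 to compound 4 is estimated at a number 2.1 degrees C higher from compound 1 to compound 4 (beyond the scatter), giving an expected value for compound 4 of 4 degrees C, with a range of 1.5 degrees C to 6.5 degrees C.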

Compound 4, shift of the target's melting temperature: 7.3 degrees C
For compound 4 the middle estimate is 3.3 degrees C below the measured one; the measured number lies above the stated range.
By their numbers in this assay, from the lowest: compounds 1 and 3 (each within the scatter of the next); then compound 2; then compound 4.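

Working notes, continued. Benzamido on this aromatic carbon gives a number 5.4 degrees C higher from compound 1 to compound 4 (beyond the scatter), and it also exceeds the cyclohexyl amide, with a number 1.6 degrees C higher from compound 2 to compound 4 (beyond the scatter), so compound 4 stands highest of the four with every step to the others beyond the scatter. The step of a number 5.0 degrees C higher from compound 3 to compound 4 (beyond the scatter) shows that an amide at this position does not in itself bring the gain, since compound 3 remains within the scatter of compound 1. No measured evidence at hand accounts for these steps.

Compound 4 differs from compound 2 both in the missing methylene and in the aromatic ring, so the two changes cannot be told apart here; benzamidomethyl or cyclohexanecarboxamido would separate them. As far as these compounds go, whether the carbonyl is needed at all stays open, and a plain amine or a benzylamine at this position would bear on that.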